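One halophenylamino swap on a weakly active core

This account rests on a few compounds, and the source may have more. Where it says the series, first, only, none or still open, it means among the compounds named here.

In a functional assay on NCI-H1299 cells (Homo sapiens) for antiproliferative activity, read by MTT assay, with a stated time of 72 h (on this read-out lower numbers stand for stronger inhibition and higher numbers for weaker inhibition), compound 1 `O=C(C1=C(OC2CCCCC2)C(=O)N(CCCn2ccnc2)C1c1ccc(Br)cc1)c1ccccc1` gives 19900 nM.
Compound 2 `O=C(C1=C(Nc2ccc(I)cc2)C(=O)N(CCCn2ccnc2)C1c1ccc(Br)cc1)c1ccccc1` gives 19400 nM in this assay.

Within the data shown here, compound 2 stands beside compound 1 on these numbers; the only measured step, a 1.0-fold lower number from compound 1 to compound 2 (0.01 log units; within the scatter), lies within the scatter, so the two compounds are not separated. Compound 3 `O=C(C1=C(Nc2ccccc2Br)C(=O)N(CCCn2ccnc2)C1c1ccc(Br)cc1)c1ccccc1` differs from compound 2 by 2-bromophenyl in place of 4-iodophenyl on an amine nitrogen. Among the measured compounds shown here, no measured step touches this change: the single step from compound 1 to compound 2 concerns a different part of the shared core and is itself within the scatter, so it offers no direction for an exchange of one haloaryl group for another on the amine nitrogen. On that basis compound 3 is expected to show no step beyond the scatter, a 1.0-fold higher number from compound 2 to compound 3 (0.01 log units; within the scatter). The estimate for compound 3 in this assay is therefore 20000 nM, with a range from 7000 nM to 60000 nM.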

Compound 3, half-maximal inhibitory concentration: 15600 nM
For compound 3 the middle estimate is 1.3-fold (0.11 log units) above the measured one; measured number inside the range.
By their numbers in this assay, from the lowest: compounds 3, 2 and 1 (each within the scatter of the next).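

In this assay the exchange on the amine nitrogen (a 1.2-fold lower number from compound 2 to compound 3 (0.09 log units; within the scatter)) lies within the scatter, so 2-bromophenyl and 4-iodophenyl are not separated at this place. The exchange on the double-bonded ring carbon (a 1.3-fold lower number from compound 1 to compound 3 (0.11 log units; within the scatter)) also lies within the scatter, so (2-bromophenyl)amino, like (4-iodophenyl)amino, is not separated from cyclohexyloxy. Nothing available bears on why these compounds are not separated.

The halogen and its place on the phenyl ring change together between compound 2 and compound 3, so the effect of either alone remains open, as would be shown by 4-bromophenyl on the amine nitrogen. Also open, from the compounds shown here alone, is whether a phenyl ring carrying a carboxylic acid or an amine, or a longer alkyl chain in place of the phenyl ring, would stand apart from these compounds.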